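Amide Replacing Fluoro on the Fused Ring: Compound 4

The source may hold more compounds than are shown below. What is called first, only, known or untested is meant among the compounds shown, and "the series" means these compounds.

Measured so far:
compound 1 `CCC1C(=O)N(C)c2cnc(-n3ccc4cc(C(N)=O)ccc43)nc2N1c1ccn(C)n1`: 27400 nM
compound 2 `CCC1C(=O)N(C)c2cnc(-n3ccc4cc(C(=O)NCC(C)C)ccc43)nc2N1c1ccn(C)n1`: 4970 nM
compound 3 `CCC1C(=O)N(C)c2cnc(-n3ccc4cc(F)ccc43)nc2N1c1ccn(C)n1`: "not active" (no number reported)

In a functional assay on HeLa cells (Homo sapiens) for antiproliferative activity, read by CCK-8 assay, with a stated time of 72 h (on this read-out higher numbers stand for weaker inhibition of growth and lower numbers for stronger inhibition of growth), compound 3 stands without a number; it is recorded as "not active" (no number reported) only. Compound 4 `CCNC(=O)c1ccc2c(ccn2-c2ncc3c(n2)N(c2ccn(C)n2)C(CC)C(=O)N3C)c1` differs from it by ethylcarbamoyl in place of fluoro on an aromatic carbon. Among the measured compounds shown here, the one measured step that bears on this is the amide series: a 5.5-fold lower number from compound 1 to compound 2 (0.74 log units; beyond the scatter), so a substituted amide at this place gives a measurable number, and ethylcarbamoyl sits between the hydrogen-bearing amide of compound 1 and the isobutyl amide of compound 2. For compound 4 a number in this assay between those of compound 1 and compound 2 is therefore expected, with a clear chance that only a limit is returned, as for compound 3. Compound 4 is estimated at 11000 nM, range 3500 nM to 35000 nM.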

Compound 4, concentration for 50% growth inhibition: 11100 nM
For compound 4 the middle estimate is 1.0-fold (0.00 log units) below the measured one; measured number inside the range.
By their numbers in this assay, from the lowest: compound 2; then compound 4; then compound 1.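

In this assay the amide series now has an intermediate point: ethyl on the amide nitrogen already lowers the number (a 2.5-fold lower number from compound 1 to compound 4 (0.39 log units; beyond the scatter)), while the shorter chain gives up part of the isobutyl gain (a 2.2-fold higher number from compound 2 to compound 4 (0.35 log units; beyond the scatter)). Among compounds 1, 4 and 2 the number thus falls from hydrogen through ethyl to isobutyl, with none of the three against this order. The step from fluoro to ethylcarbamoyl cannot be read as a size, and nothing here gives a reason for these steps.

Open, on these data alone, is whether a chain longer than isobutyl on the amide nitrogen lowers the number further. Also open, as far as these compounds go, is how a carboxylic acid or an amine would read at this aromatic carbon.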